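The compounds below may be only part of what the source reports. "The series", "measured", "known", "first", "only" and "open" are said of these compounds alone.

Compound 1 `O=C(Nc1ccccc1)c1cccc(/C=C2\CC(=O)N(c3ccccc3)C2=O)c1` is one of three members of a shared core that have been tested in an ADME assay on HCT-116 cells (Homo sapiens) for cytotoxicity, read by MTT assay, with a stated time of 72 h (a higher number here means a weaker inhibitor, a lower number a stronger inhibitor), and in that test compound 1 gives > 100000 nM, which is a limit of the assay rather than a number. Compound 2 `Cc1ccc(N2C(=O)C/C(=C\c3cccc(C(=O)Nc4cccc(F)c4)c3)C2=O)cc1` gives > 100000 nM in this assay, again a limit and not a number. Compound 3 `COc1ccc(NC(=O)c2cccc(/C=C3\CC(=O)N(c4ccc(C)cc4)C3=O)c2)cc1` gives > 100000 nM in this assay, also a limit rather than a number. Within the data shown here, the only step between two measured compounds that differ in one place, 4-methoxyphenyl in place of 3-fluorophenyl on an amide-type nitrogen, reads a step that the two limits leave unreadable from compound 2 to compound 3, so its size cannot be read. In short, the whole picture so far is the limit of > 100000 nM in this assay, at which 3 of the 3 values shown sit.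

Compound 4 `O=C(c1cccc(/C=C2\CC(=O)N(c3ccccc3)C2=O)c1)N1CCCC1` has not yet been measured. It differs from compound 1 by pyrrolidin-1-yl in place of anilino on a carbonyl carbon. Among the measured compounds shown here, no measured step involves a change on the carbonyl carbon, and the one step that is available is unreadable, so no direction can be taken from it; what is known is that compound 1 sits at the limit with > 100000 nM in this assay. On that basis compound 4 is expected to stay at or near the same limit, a step that the limit leaves unreadable from compound 1 to compound 4. The estimate for compound 4 is therefore 150000 nM, with a range from 50000 nM to 500000 nM in this assay.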

Compound 4, half-maximal inhibitory concentration: > 100000 nM
Compound 4 was reported as a limit; the forecaster's own chance of this, stated with the estimate: 85%; the middle value lies beyond the limit too.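

Compound 1 and compound 4 are both reported only as limits, not numbers, so the change from anilino to pyrrolidin-1-yl gives no step that can be read, and the whole set stands in the same place: the limit of > 100000 nM in this assay, at which 4 of the 4 values shown sit.

The compounds shown leave open whether any change to the shared core would give a readable number in this assay.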